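Methylbenzyl positional change on the amide nitrogen of the core

This account rests on a few compounds, and the source may have more. Where it says the series, first, only, none or still open, it means among the compounds named here.

Measured compounds:
compound 1, `Cc1ccc(CN2CCc3ncn(COCc4ccccc4)c3/C(=C/c3ccccc3)C2=O)cc1` — 21200 nM
compound 2, `Cc1cccc(CN2CCc3ncn(COCc4ccccc4)c3/C(=C/c3ccccc3)C2=O)c1` — 26300 nM

In a functional assay on A2780 cells (Homo sapiens) for inhibition, read by MTT assay, with a stated time of 72 h (on this read-out higher numbers stand for weaker inhibition and lower numbers for stronger inhibition), compound 1 gives 21200 nM, the lowest of the two numbers recorded; its nearest neighbour is compound 2, which in this assay gives 26300 nM. For the measured compounds named here, the one step so far, a 1.2-fold higher number from compound 1 to compound 2 (0.09 log units; within the scatter), keeps both compounds on one level.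

Compound 3, `Cc1ccccc1CN1CCc2ncn(COCc3ccccc3)c2/C(=C/c2ccccc2)C1=O`, remains to be measured. It differs from compound 1 by 2-methylphenyl in place of 4-methylphenyl on a saturated chain carbon bound to an amide-type nitrogen in a ring. Going by the values given here, the only step that bears on it is the one from compound 1 to compound 2, where the same methyl was moved on the same ring and the result stayed within the scatter. Nothing else about the series speaks for a change in either direction, so no step beyond the scatter is expected here.

Compound 3 is therefore estimated at 24000 nM, with a range from 12000 nM to 48000 nM, which is an expected step of a 1.1-fold higher number from compound 1 to compound 3 (0.05 log units; within the scatter).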

Compound 3, half-maximal inhibitory concentration: 25300 nM
Compound 3: the middle estimate sits 1.1-fold (0.02 log units) below what was measured; low and high end bracket the measured number.
By their numbers in this assay, from the lowest: compounds 1, 3 and 2 (each within the scatter of the next).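

In this assay, 2-methylphenyl in place of 4-methylphenyl gives a 1.2-fold higher number from compound 1 to compound 3 (0.08 log units; within the scatter), and 2-methylphenyl in place of 3-methylphenyl gives a 1.0-fold lower number from compound 2 to compound 3 (0.02 log units; within the scatter). All three methylphenyl groups on this saturated chain carbon bound to the amide-type nitrogen therefore stand on one level, so the result seen for the first pair also holds for 2-methylbenzyl. No supporting data are available to explain this flat result.

On these data alone, all three compounds keep a methyl group on the phenyl ring, so it remains open how an unsubstituted benzyl group, an amine or carboxylic acid on the ring, or a longer chain carrying the ring would read. These three compounds cannot show whether any change at this place gives a step beyond the scatter.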